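The source may report more compounds than this note shows. Statements on the series, on what has been measured and on what is new or still open speak of the compounds shown alone.

Compound 1, `COc1ccc(NC(=O)c2nc(-c3cc(OC)c(OC)c(OC)c3)n(-c3ccc(OC)cc3)n2)cc1`, gives 86% in a functional assay on the whole organism for inhibition, with Rattus norvegicus as the target, read by paw edema, with stated times of 30 min and 3 h, at a dose of 0.28 mmol/kg by the oral route; a higher number here means more inhibition at the dose given (going by the name of the read-out), a lower number less inhibition. Compound 2, `COc1ccc(-n2nc(C(=O)Nc3ccc(C(=O)O)cc3)nc2-c2cc(OC)c(OC)c(OC)c2)cc1`, gives 95% in this assay, and the step of a number 9 percentage points higher from compound 1 to compound 2 (within the scatter) lies within the scatter, so the two numbers stand together rather than in any order. Compound 2 thus sits at the top of the two numbers shown, yet only by an amount the scatter covers.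

Compound 3, `COc1ccc(-n2nc(C(=O)Nc3ccccc3)nc2-c2cc(OC)c(OC)c(OC)c2)cc1`, has not yet been measured. It differs from compound 2 in one place: hydrogen in place of carboxy on an aromatic carbon.

Going by the values given here, the single step measured so far, a number 9 percentage points higher from compound 1 to compound 2 (within the scatter), is the only one that bears on the change, and it concerns the same aromatic carbon, where carboxy entered in place of methoxy without moving the number beyond the scatter. Taking carboxy away again and leaving hydrogen is therefore expected to change the number little, if at all, with no direction preferred beyond a slight lean downward. The step from compound 2 to compound 3 is estimated as a number 10 percentage points lower from compound 2 to compound 3 (within the scatter). Compound 3 is expected to give about 85% in this assay, within a range from 68% to 96%.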

Compound 3, a percentage reported as inhibition, in the whole organism at one dose (the size of the read-out at that dose, not a potency): 69%
Beside the measured number, compound 3's estimate is 16 percentage points above it, within the range that was stated.
By their numbers in this assay, from the lowest: compound 3; then compounds 1 and 2 (each within the scatter of the next).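

Going by these compounds alone, until this result, the aromatic carbon para to a large group had carried only carboxy and methoxy, two groups whose numbers stand within the scatter of each other, so the position could have looked indifferent to what it holds. With hydrogen at that carbon, this assay does separate the compounds: the result is a number 26 percentage points lower from compound 2 to compound 3 (beyond the scatter), and also a number 17 percentage points lower from compound 1 to compound 3 (beyond the scatter), so hydrogen stands apart from both groups while they do not stand apart from each other. Among these compounds, then, a group at this carbon goes with more inhibition at the dose given, whether that group is carboxy or methoxy, and the change from 4-carboxyphenyl to phenyl is not a neutral one.

Nothing available here bears on why hydrogen stands apart from the other two groups. On these data alone, whether an amine, a chlorine atom or a longer chain such as ethoxy at this carbon would stand with carboxy and methoxy or with hydrogen remains open, as does whether the same separation would hold at other doses.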